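Adding a methoxy group in a small cytotoxicity series

A few compounds are considered here, and "the series" means these few. Any claim that something is new, unique, unknown or untested is made for them only; others in the source may bear on it.

Of the compounds shown here, three have been measured in a functional assay on HCT-116 cells (Homo sapiens) for cytotoxicity, read by sulforhodamine B assay, with a stated time of 48 h, tested at 0.1 uM; a higher number here means a weaker effect of the compound at the concentration tested, a lower number a stronger effect. Compound 3 `COc1ccc(-c2cc(/C=C/C(=O)c3ccc(N)cc3)[nH]n2)cc1OC` gives 101%. Compound 1 `COc1cc(-c2cc(/C=C/C(=O)c3ccc(N)cc3)[nH]n2)cc(OC)c1OC` gives 97%; the change from compound 3 to compound 1 is methoxy in place of hydrogen on an aromatic carbon, and the step it made is a number 4 percentage points lower from compound 3 to compound 1 (within the scatter). Compound 2 `COc1ccc(C(=O)/C=C/c2cc(-c3cc(OC)c(OC)c(OC)c3)n[nH]2)cc1OC` gives 100%; the step from compound 1 to compound 2 is a number 3 percentage points higher from compound 1 to compound 2 (within the scatter). The difference between the cores of compound 2 and compound 3 is not broken down here.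

Compound 4 `COc1cc(C(=O)/C=C/c2cc(-c3cc(OC)c(OC)c(OC)c3)n[nH]2)cc(OC)c1OC` has not yet been measured. It differs from compound 2 by methoxy in place of hydrogen on an aromatic carbon. Among the measured compounds shown here, this is the same change as the one from compound 3 to compound 1: the place is described in the same words in both cases, ortho to a methoxy group, meta to a large group, meta to a methoxy group. The one measured occurrence of the change gave a step within the scatter, and the three measured values sit close to one another at this concentration, so there is little room for the number to move upward and no indication in the measured pair that it moves downward.

The step from compound 2 to compound 4 in this assay is expected to be a number 2 percentage points lower from compound 2 to compound 4 (within the scatter), which rests on the earlier occurrence of the change, a number 4 percentage points lower from compound 3 to compound 1 (within the scatter). For compound 4 in this assay the expected value is 98%, with a range from 90% to 105%.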

Compound 4, a percentage reported as activity, at one concentration (the size of the read-out at that concentration, not a potency): 104%
The estimate for compound 4 lay 6 percentage points below the measured number; the measured number falls inside the stated range.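

In this assay, methoxy in place of hydrogen on an aromatic carbon now gives a number 4 percentage points higher from compound 2 to compound 4 (within the scatter). Set beside the earlier occurrence of the same change, the two steps point in opposite directions, but the gap between them does not exceed what repeated measurement allows: the same change on two cores in this assay, a number 4 percentage points lower (within the scatter) from compound 3 to compound 1 and a number 4 percentage points higher (within the scatter) from compound 2 to compound 4, 8 percentage points apart, within the scatter of two such steps. On these two cores, then, the change leaves the read-out within the scatter each time, and neither step offers a direction that could be carried from one core to the other; this supports no more than the statement that no step beyond the scatter has appeared on either core, and it does not show that the change would stay as small on a core whose number sits well lower.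

Left open is whether the place ortho to a methoxy group, meta to a large group, meta to a methoxy group would respond differently to a group other than methoxy, such as a longer chain like ethoxy, a fluoro group or a carboxylic acid. Also open is whether any of these compounds would separate from the others at a higher tested concentration.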